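The compounds below may be only part of what the source reports. "The series", "measured", "known", "first", "only" and "open" are said of these compounds alone.

Compound 1 `CO[C@@]12CCN(C)C[C@H]1[C@H](c1ccc3ccccc3c1)C(C#N)=C(N)O2` and compound 2 `CCN1CC[C@@]2(OC)OC(N)=C(C#N)[C@@H](c3ccc4ccccc4c3)[C@@H]2C1` share one core and differ by methyl in place of hydrogen on a saturated chain carbon bound to an amine nitrogen in a ring. In a functional assay on trachea (Cavia porcellus) (on this read-out lower numbers stand for stronger inhibition and higher numbers for weaker inhibition), compound 1 gives 24200 nM, and compound 2 gives 28300 nM; the step is a 1.2-fold higher number from compound 1 to compound 2 (0.07 log units; within the scatter). Compound 3 `CO[C@@]12CCN(C)C[C@H]1[C@H](c1ccc(C)cc1)C(C#N)=C(N)O2` carries a different core, and the difference between the two cores is not broken down here. In this assay compound 3 gives 13200 nM. Compound 4 `CCN1CC[C@@]2(OC)OC(N)=C(C#N)[C@@H](c3ccc(C)cc3)[C@@H]2C1` differs from compound 3 by methyl in place of hydrogen on a saturated chain carbon bound to an amine nitrogen in a ring, the same change that was made from compound 1 to compound 2. Since that earlier change gave a 1.2-fold higher number from compound 1 to compound 2 (0.07 log units; within the scatter), the step from compound 3 to compound 4 is expected to be similar, a 1.2-fold higher number from compound 3 to compound 4 (0.08 log units; within the scatter). Compound 4 is therefore estimated at 16000 nM, with a likely range from 8000 nM to 32000 nM.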

Compound 4, half-maximal inhibitory concentration: 16800 nM
The estimate for compound 4 lay 1.1-fold (0.02 log units) below the measured number, and the stated range covers the measured number.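

In this assay, putting methyl in place of hydrogen on the core of compound 3 gives a 1.3-fold higher number from compound 3 to compound 4 (0.10 log units; within the scatter). The change therefore carries over between these two cores as a small step of much the same size, and the two steps agree: the same change on two cores in this assay, a 1.2-fold higher number (0.07 log units; within the scatter) from compound 1 to compound 2 and a 1.3-fold higher number (0.10 log units; within the scatter) from compound 3 to compound 4, 1.1-fold (0.04 log units) apart, within the scatter of two such steps

Within the data shown here, both steps lie within the scatter, so this shows only that the change has no clear effect on either core; two cores cannot show that the same would hold across the whole series. The compounds shown leave open whether a longer chain, such as propyl or butyl, or a benzyl group in the same place would give a step beyond the scatter.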